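The source may report more compounds than this note shows. Statements on the series, on what has been measured and on what is new or still open speak of the compounds shown alone.

Compound 1 `CC(C)(C)c1ccc(C(=O)NC(=O)c2ccccc2O)cc1`: in an ADME assay on L6 cells (Rattus norvegicus) for cytotoxicity, read by resazurin assay, with a stated time of 72 h (on this read-out higher numbers stand for weaker inhibition and lower numbers for stronger inhibition), compound 1 gives 2.3 ug/mL.
Compound 3 `CCOc1ccc(C(=O)NC(=O)c2ccccc2O)cc1`: in this assay compound 3 gives 17 ug/mL.
Compound 2 `O=C(NC(=O)c1ccccc1O)c1ccc(-c2ccccc2)cc1`: in this assay compound 2 gives only a limit, > 100 ug/mL, and no number (the limit of > 100 ug/mL in this assay, at which 1 of the 3 values shown sits).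

Compound 2 therefore stands at the top of the scale, with only a range known, while compound 1 and compound 3 lie well inside the measured region. Compound 4 `CCCCOc1ccc(C(=O)NC(=O)c2ccccc2O)cc1` differs from compound 2 by butoxy in place of phenyl on an aromatic carbon. Within the data shown here, two measured steps bear on this change: an at least 5.8-fold lower number from compound 2 to compound 3 (0.76 log units; beyond the scatter), where an alkoxy chain likewise replaced phenyl, and an at least 43-fold higher number from compound 1 to compound 2 (1.63 log units; beyond the scatter). Both show the phenyl compound as the weakest inhibitor of the three. A downward step is thus expected, an at least 10-fold lower number from compound 2 to compound 4 (1.00 log units; beyond the scatter). Compound 4 is estimated at 10 ug/mL, between 3 ug/mL and 40 ug/mL.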

Compound 4, half-maximal inhibitory concentration: 13 ug/mL
For compound 4 the middle estimate is 1.3-fold (0.11 log units) below the measured one; the range from low to high includes it.
By their numbers in this assay, from the lowest: compound 1; then compounds 4 and 3 (each within the scatter of the next). At a limit, above all of these: compound 2.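

In this assay, butoxy and ethoxy at this position read alike: a 1.3-fold lower number from compound 3 to compound 4 (0.12 log units; within the scatter), and butoxy, like ethoxy, stands apart from tert-butyl: a 5.7-fold higher number from compound 1 to compound 4 (0.75 log units; beyond the scatter). Butoxy in place of phenyl gives an at least 7.6-fold lower number from compound 2 to compound 4 (0.88 log units; beyond the scatter), so the gap from phenyl holds for a second alkoxy chain. That step gives a bound and not a size, since compound 2 is known only as a limit: the limit of > 100 ug/mL in this assay, at which 1 of the 4 values shown sits.

The compounds shown leave open whether a longer chain such as octyloxy would still read like ethoxy and butoxy. They also leave open how an amine or a carboxylic acid at this position would read.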